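Swapping the dichlorophenyl amide for an isopropyl amide

The compounds below may be only part of what the source reports. "The series", "measured", "known", "first", "only" and "open" are said of these compounds alone.

Compound 1, `COc1cc(/C=C/C(=O)c2cccc(NC(=O)c3cccs3)c2)ccc1O`, carries a thiophen-2-yl group on the amide carbonyl carbon of a shared core. In a functional assay on HUVEC cells (Homo sapiens) for inhibition, tested at 5 ug/mL (a higher number here means a stronger effect of the compound at the concentration tested, a lower number a weaker effect), compound 1 gives 80%. Compound 2, `COc1cc(/C=C/C(=O)c2cccc(NC(=O)c3ccc(Cl)cc3Cl)c2)ccc1O`, has 2,4-dichlorophenyl in that place instead, and in this assay compound 2 gives 51%. That single change produced a number 29 percentage points lower from compound 1 to compound 2 (beyond the scatter). Among the measured compounds shown here, on the two numbers so far, compound 2 therefore stands at the lower of the pair, with compound 1 as its only neighbour.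

Compound 3, `COc1cc(/C=C/C(=O)c2cccc(NC(=O)C(C)C)c2)ccc1O`, is the next step from compound 2: isopropyl in place of 2,4-dichlorophenyl on a carbonyl carbon. For the measured compounds named here, the only measured step that bears on this position is a number 29 percentage points lower from compound 1 to compound 2 (beyond the scatter), which shows that exchanging the group on this carbonyl carbon can shift the read-out by a modest amount beyond the scatter. Going by the values given here, no measured pair shows what a group without a ring does here, so the direction is open. Among the compounds with values here, the expectation for compound 3 is a value near the middle of the two known numbers, estimated at 60%, with a range from 35% to 85%, which would mean a number 9 percentage points higher from compound 2 to compound 3 (within the scatter).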

Compound 3, a percentage reported as inhibition, at one concentration (the size of the read-out at that concentration, not a potency): 51%
Compound 3: middle estimate off by 9 percentage points, on the high side; measured number inside the range.
By their numbers in this assay, from the lowest: compounds 2 and 3 (each within the scatter of the next); then compound 1.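

In this assay the exchange of 2,4-dichlorophenyl for isopropyl gives no change at the digits printed from compound 2 to compound 3 (within the scatter), so the presence of a ring on this carbonyl carbon is not what separates these two compounds, even though one group holds a six-membered aromatic ring and the other holds no ring at all. Thiophen-2-yl is the group that stands apart, with a number 29 percentage points lower from compound 1 to compound 3 (beyond the scatter), a step of the same size as the one already seen going to the dichlorophenyl compound. The higher reading of compound 1 therefore cannot be credited to simply having a ring, since compound 2 has a ring and compound 3 has none and they read alike, and no supporting data are available to give a reason for the thiophen-2-yl result.

From the compounds shown here alone, whether that reading belongs to thiophen-2-yl in particular remains open, and furan-2-yl, plain phenyl or a longer chain such as n-butyl on the same carbonyl carbon would speak to that. These figures also come from a single concentration, so they leave open whether compound 2 and compound 3 would still read alike across a range of concentrations.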